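The source may hold more compounds than are shown below. What is called first, only, known or untested is meant among the compounds shown, and "the series" means these compounds.

In a functional assay on Jurkat cells (Homo sapiens) for cytotoxicity, with a stated time of 72 h (on this read-out lower numbers stand for an effect already at smaller amounts and higher numbers for an effect only at larger amounts of compound), compound 3 `C=C[C@@](C)(/C=C/c1ccc(O)c(/C=C/C(=O)OCc2ccccc2)c1)CCC=C(C)C` gives > 49000 nM, which is a limit of the assay and not a number. Compound 1 `C=C[C@@](C)(/C=C/c1ccc(O)c(/C=C/C(=O)c2ccccc2)c1)CCC=C(C)C` gives > 49000 nM, also a limit. Compound 2 `C=C[C@@](C)(/C=C/c1ccc(O)c(/C=C/C#N)c1)CCC=C(C)C` gives > 49000 nM, again a limit. Compound 3 therefore has no measured value to stand on, and it cannot be ranked against the other two.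

The next compound, compound 4 `C=C[C@@](C)(/C=C/c1ccc(O)c(/C=C/C(=O)O)c1)CCC=C(C)C`, has not yet been measured. Its change from compound 3 is hydrogen in place of benzyl on an oxygen next to a carbonyl group, so that benzyloxycarbonyl becomes carboxy.

Among the measured compounds shown here, three measured steps bear on this change: a step that the two limits leave unreadable from compound 1 to compound 3, a step that the two limits leave unreadable from compound 2 to compound 3 and a step that the two limits leave unreadable from compound 1 to compound 2. None has a size that can be read, so they give no measure of how much this part of the chain matters. For the measured compounds named here, the only guide is the limit of > 49000 nM in this assay, at which 3 of the 3 values shown sit. With compound 3 at > 49000 nM, no gain in this assay is foreseen, and another limit is the most likely report.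

The expected change is a step that the limit leaves unreadable from compound 3 to compound 4, an estimate that carries no clear direction. For compound 4 the estimated value is 60000 nM, with an expected range from 25000 nM to 150000 nM.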

Compound 4, half-maximal effective concentration: > 49000 nM
Compound 4 was reported as a limit; the forecaster's own chance of this, stated with the estimate: 85%; the middle value is on the limit's open side.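

Compound 4, like compounds 1, 2 and 3, is reported only as a limit in this assay, so no step among these four compounds can be read: the limit of > 49000 nM in this assay, at which 4 of the 4 values shown sit.

The compounds shown leave open whether any group at this end of the chain can bring a measurable effect in this assay, and how much the groups compared here matter.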